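Swapping an aromatic ring for a non-aromatic one

The source may hold more compounds than are shown below. What is called first, only, known or untested is meant among the compounds shown, and "the series" means these compounds.

In a functional assay (thoracic aorta) with Rattus norvegicus as the target, in the presence of a further agent that is not named here (a lower number here means that less compound is needed, a higher number that more compound is needed for the effect), compound 1 `S=C=Nc1ccc(CCC2=NCCN2)cc1` gives 14900 nM and compound 2 `S=C=Nc1ccc(Cc2ncc[nH]2)cc1` gives 25500 nM and these two numbers lie within the usual scatter of each other. Compound 3 `S=C=Nc1ccc(CC2=NCCN2)cc1` differs from compound 2 in one place, on a saturated chain carbon bound to an aromatic carbon (a group of 5 heavy atoms (3 carbon, 2 nitrogen; one five-membered non-aromatic ring with 2 hetero atoms) in place of a group of 5 heavy atoms (3 carbon, 2 nitrogen; one five-membered aromatic ring with 2 hetero atoms), on a saturated chain carbon bound to an aromatic carbon). Among the compounds with values here, no measured pair shows this swap directly. Compound 1 carries the same non-aromatic ring and stands at 14900 nM so only a modest move toward a lower number is expected in this assay and the estimated step is a 4.3-fold lower number from compound 2 to compound 3 (0.63 log units; beyond the scatter) on this reading. For compound 3 the estimate is 6000 nM with an expected range from 1000 nM to 30000 nM in this measurement.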

Compound 3, half-maximal effective concentration: 43000 nM
The estimate for compound 3 lay 7.2-fold (0.86 log units) below the measured number, outside the stated range (above it).
By their numbers in this assay, from the lowest: compounds 1, 2 and 3 (each within the scatter of the next, the first and the last beyond it).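

In this assay, within the data shown here, the first direct pair for this swap gives a 1.7-fold higher number from compound 2 to compound 3 (0.23 log units; within the scatter). At this place, on a saturated chain carbon bound to an aromatic carbon, the aromatic and the non-aromatic five-membered rings therefore cannot be told apart. Nothing measured here indicates why the two rings read alike. The compounds shown leave open whether an open-chain group at the same place, such as an amine or a carboxylic acid, would give a number clearly different from those of these rings.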